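The compounds below may be only part of what the source reports. "The series", "measured", "known", "first", "only" and "open" are said of these compounds alone.

Of the compounds shown here, two sharing one core have so far been tested in an assay on Sf9 cells for inhibition of histone deacetylase 11 (Homo sapiens), read by fluorescence, tested at 0.5 uM; on this read-out higher numbers stand for more inhibition at the one concentration tested (going by the name of the read-out) and lower numbers for less inhibition. Compound 1, with the structure `O=C(NO)c1ccc(-c2cn([C@H]3C[C@@H](C(=O)O)N(Cc4ccccc4)C3)nn2)cc1`, gives < 10% in this assay, and this is a limit of the assay rather than a number. Compound 2, with the structure `O=C(/C=C/c1cn([C@H]2C[C@H](C(=O)O)N(Cc3ccccc3)C2)nn1)NO`, gives 14% in this assay. Compound 2 therefore holds the only number shown, while the other value is a limit; the two lie within the usual scatter of each other, so no order between them can be read. What the data show is that (the limit of < 10% in this assay, at which 1 of the 2 values shown sits).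

Compound 3, with the structure `O=C(NO)c1ccc(-c2cn([C@H]3C[C@H](C(=O)O)N(Cc4ccccc4)C3)nn2)cc1`, has not yet been measured in this assay. It differs from compound 2 in one place: 4-(hydroxycarbamoyl)phenyl in place of 2-(hydroxycarbamoyl)ethenyl on an aromatic carbon. For the measured compounds named here, no measured pair shows this change, so nothing indicates how large a step it brings. Both measured values sit at or near the limit, and the step of a number 4 percentage points lower from compound 2 to compound 3 (within the scatter) is expected to be no larger than the scatter, keeping the value in the same low region. Compound 3 is thus estimated to give 10% in this assay, within a range from 2% to 22%, with a fair chance that only a limit is reported.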

Compound 3, a percentage reported as inhibition, at one concentration (the size of the read-out at that concentration, not a potency): < 10%
Compound 3 gave a limit, no number; the forecaster's own chance of this, stated with the estimate: 45%; the middle value lies on the limit itself.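

In this assay, for the compounds shown here, putting 4-(hydroxycarbamoyl)phenyl in place of 2-(hydroxycarbamoyl)ethenyl on this aromatic carbon gives a number at least 4 percentage points lower from compound 2 to compound 3 (that floor lies within the scatter), so this first look at the change shows that the larger aromatic group brings no step that can be told from the scatter, even though the result for compound 3 is a limit. Compound 1 and compound 3 both end at a limit, so the step between them cannot be read, and the new pair says nothing about the stereocentre at the saturated ring carbon: the fact that compounds 1 and 3 differ only in the configuration as drawn. The series now rests mostly on one limit rather than on numbers: the limit of < 10% in this assay, at which 2 of the 3 values shown sit.

The compounds shown leave open whether any other group on this aromatic carbon, such as a longer chain carrying the hydroxycarbamoyl group or an amine, would give a value clearly beyond the scatter. They also leave open whether an amide in place of the carboxylic acid on the shared core would move the read-out at all.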